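The source may hold more compounds than are shown below. What is called first, only, known or untested is meant among the compounds shown, and "the series" means these compounds.

Measured compounds:
compound 1, `Cc1cc(C)cc(S(=O)(=O)c2c(C(=O)NCc3ccccc3O)[nH]c3ccc(Cl)cc23)c1`: 23800 nM
compound 2, `Cc1cc(C)cc(S(=O)(=O)c2c(C(=O)NCc3cccc(O)c3)[nH]c3ccc(Cl)cc23)c1`: 27000 nM
compound 3, `Cc1cc(C)cc(S(=O)(=O)c2c(C(=O)NCC(=O)NCc3ccccc3O)[nH]c3ccc(Cl)cc23)c1`: > 47300 nM

In an ADME assay on MT4 cells (Homo sapiens) for cytotoxicity, read by MTT assay (a lower number here means that less compound is tolerated, a higher number that more compound is tolerated), compound 1 gives 23800 nM and compound 2 gives 27000 nM. For compound 3 the value > 47300 nM is a limit of the assay, not a number. The change from compound 1 to compound 2 is 3-hydroxyphenyl in place of 2-hydroxyphenyl on a saturated chain carbon bound to an amide-type nitrogen; it produced a 1.1-fold higher number from compound 1 to compound 2 (0.05 log units; within the scatter). Compound 4, `Cc1cc(C)cc(S(=O)(=O)c2c(C(=O)NCC(=O)NCc3cccc(O)c3)[nH]c3ccc(Cl)cc23)c1`, is not yet measured; it arises from compound 3 by 3-hydroxyphenyl in place of 2-hydroxyphenyl on a saturated chain carbon bound to an amide-type nitrogen, the same change in the same place. The cores of compound 1 and compound 3 differ by (2-hydroxybenzyl)carbamoyl in place of 2-hydroxyphenyl on a saturated chain carbon bound to an amide-type nitrogen. Because one value sits at the limit of > 47300 nM in this assay, at which 1 of the 3 values shown sits, compound 3 offers only a floor. The step from compound 3 to compound 4 is expected to be a step that the limit leaves unreadable from compound 3 to compound 4, small like the earlier one, because a 1.1-fold higher number from compound 1 to compound 2 (0.05 log units; within the scatter) lay within the scatter. Compound 4 is estimated at 50000 nM, most likely reported again only as a limit.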

Compound 4, half-maximal cytotoxic concentration: > 47500 nM
Compound 4 ended at the assay's limit; the forecaster's own chance of this, stated with the estimate: 65%; the middle value lies beyond the limit too.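

In this assay compound 4 gives > 47500 nM as a limit of the assay, not a number. Compound 3 also stands at a limit, so the change from 2-hydroxyphenyl to 3-hydroxyphenyl cannot be read on this core, and nothing shows whether it stays as small here as on the core of compound 1. The data give an at least 1.7-fold higher number from compound 2 to compound 4 (0.24 log units; that floor lies within the scatter) and an at least 1.9-fold higher number from compound 1 to compound 4 (0.30 log units; that floor lies within the scatter) as floors only.

Going by these compounds, the true size of the change on the longer core remains open. Also open, on these data alone, is whether an amine or a carboxylic acid in place of the hydroxyl group, or a longer chain, would give a readable number rather than a limit.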